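A few compounds are considered here, and "the series" means these few. Any claim that something is new, unique, unknown or untested is made for them only; others in the source may bear on it.

Of the compounds shown here, three built on one shared core have been measured so far: compound 1 `COc1nc(-c2cc3ccccc3o2)cc(-c2ccccc2)c1C#N`, compound 2 `COc1nc(-c2cc3ccccc3o2)cc(-c2ccc(Cl)cc2)c1C#N` and compound 3 `CCOc1nc(-c2cc3ccccc3o2)cc(-c2ccc(Cl)cc2)c1C#N`. In a functional assay on aorta (strain Wistar) for inhibition, with Thoracic aorta (Rattus norvegicus) as the target (a lower number here means a stronger inhibitor, a higher number a weaker inhibitor), compound 1 gives 232000 nM. In this assay compound 2 gives 286000 nM, and compound 3 gives 221000 nM. Both steps among them, a 1.2-fold higher number from compound 1 to compound 2 (0.09 log units; within the scatter) and a 1.3-fold lower number from compound 2 to compound 3 (0.11 log units; within the scatter), stay within the scatter, so compound 3, although it carries the lowest of the three numbers, cannot be separated from compound 1 or compound 2 on these figures.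

Compound 4 `CCOc1nc(-c2cc3ccccc3o2)cc(-c2ccc(Br)cc2)c1C#N` has not yet been measured in this assay. It differs from compound 3 by bromo in place of chloro on an aromatic carbon. Among the measured compounds shown here, the one measured step at that same aromatic carbon, a 1.2-fold higher number from compound 1 to compound 2 (0.09 log units; within the scatter), lay within the scatter, and no other step speaks to a halogen swap there. Compound 4 is therefore expected to show a step of a 1.0-fold higher number from compound 3 to compound 4 (0.02 log units; within the scatter), which is no step beyond the scatter. On that basis compound 4 is estimated to give 230000 nM in this assay, with a range from 115000 nM to 460000 nM.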

Compound 4, half-maximal inhibitory concentration: 227000 nM
Compound 4: middle estimate off by 1.0-fold (0.01 log units), on the high side; low and high end bracket the measured number.
By their numbers in this assay, from the lowest: compounds 3, 4, 1 and 2 (each within the scatter of the next).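

In this assay, among the compounds shown here, the exchange of 4-chlorophenyl for 4-bromophenyl gives a 1.0-fold higher number from compound 3 to compound 4 (0.01 log units; within the scatter), so a swap of one halogen for another at this aromatic carbon, tested here for the first time, does not separate the two compounds. Together with a 1.2-fold higher number from compound 1 to compound 2 (0.09 log units; within the scatter), this makes two different changes on that carbon, and neither leaves the scatter, though the earlier step was a chloro group replacing hydrogen and this one is a bromo group replacing chloro. Nothing available bears on why this exchange leaves the number within the scatter. The compounds shown leave open whether a group of another kind on this carbon, such as an amine or a carboxylic acid, would give a step beyond the scatter. They also leave open whether a longer chain on the oxygen would do so.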